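The source may report more compounds than this note shows. Statements on the series, on what has been measured and on what is new or still open speak of the compounds shown alone.

Measured compounds in a functional assay on COLO 205 cells (Homo sapiens) for antiproliferative activity, read by MTT assay, with a stated time of 68 h; on this read-out lower numbers stand for stronger inhibition and higher numbers for weaker inhibition:
- compound 1 `O=S(=O)(Nc1ccc(F)c(C#Cc2cnc3[nH]nc(C4CC4)c3c2)c1F)c1cccnc1`: 61 nM
- compound 2 `O=S(=O)(Nc1ccc(F)c(C#Cc2cnc3[nH]nc(-c4ccncc4)c3c2)c1F)c1cccnc1`: 78 nM

Going by the values given here, compound 2 stands alongside compound 1, the only other measured compound; the two are separated by a 1.3-fold higher number from compound 1 to compound 2 (0.11 log units; within the scatter), so neither is set apart from the other in this assay.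

Compound 3 `O=S(=O)(Nc1ccc(F)c(C#Cc2cnc3[nH]nc(-c4ccccc4Cl)c3c2)c1F)c1cccnc1` differs from compound 2 by 2-chlorophenyl in place of pyridin-4-yl on an aromatic carbon. Among the compounds with values here, the one measured step at this same carbon, a 1.3-fold higher number from compound 1 to compound 2 (0.11 log units; within the scatter), exchanged a carbocycle for an aromatic heterocycle without moving the number beyond the scatter. On that basis no step beyond the scatter is expected for a 1.0-fold higher number from compound 2 to compound 3 (0.01 log units; within the scatter) in this assay. Compound 3 is therefore estimated at 80 nM, with a likely range of 30 nM to 220 nM.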

Compound 3, half-maximal inhibitory concentration: 3600 nM
Beside the measured number, compound 3's estimate is 45-fold (1.65 log units) below it, outside the stated range (above it).
By their numbers in this assay, from the lowest: compounds 1 and 2 (each within the scatter of the next); then compound 3.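

In this assay this aromatic carbon proves sensitive to its substituent, which the first two compounds, within the scatter of each other, did not reveal. Here 2-chlorophenyl brings a 46-fold higher number from compound 2 to compound 3 (1.66 log units; beyond the scatter) and a 59-fold higher number from compound 1 to compound 3 (1.77 log units; beyond the scatter) on the same carbon, so an aromatic ring of carbon only with chlorine is far less well accepted than pyridin-4-yl or cyclopropyl. No available measurement accounts for this step.

On these data alone, whether the step follows the chlorine or the carbon-only ring remains open, and plain phenyl would separate the two. As far as these compounds go, how an amine or a longer chain on this carbon would read also remains open.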